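A chlorophenyl swap on compound 3

The source may hold more compounds than are shown below. What is called first, only, known or untested is meant among the compounds shown, and "the series" means these compounds.

In a functional assay on MDA-MB-231 cells (Homo sapiens) for antiproliferative activity, read by MTT assay, with a stated time of 24 h (a lower number here means a stronger inhibitor, a higher number a weaker inhibitor), compound 1 `O=C(NNc1ccccc1Cl)c1cccc(NS(=O)(=O)c2cnc(O)nc2O)c1` gives 2090 nM. Compound 2 `O=C(NNc1ccc(F)cc1)c1cccc(NS(=O)(=O)c2cnc(O)nc2O)c1` is reported only as a limit, > 20000 nM. Compound 3 `Cc1ccccc1C(=O)NNC(=O)c1cccc(NS(=O)(=O)c2cnc(O)nc2O)c1` gives 18100 nM, the higher of the two actual numbers in the set. The data show an 8.7-fold higher number from compound 1 to compound 3 (0.94 log units; beyond the scatter), whereas an at least 1.1-fold lower number from compound 2 to compound 3 (0.04 log units; that floor lies within the scatter) gives no separation beyond the scatter.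

Compound 4 `O=C(NNC(=O)c1cccc(NS(=O)(=O)c2cnc(O)nc2O)c1)c1cccc(Cl)c1` differs from compound 3 in one group: 3-chlorophenyl in place of 2-methylphenyl on a carbonyl carbon, with 3-chlorophenyl in place of 2-methylphenyl on a carbonyl carbon. Among the measured compounds shown here, no measured step makes this exact change. The nearest guides are an at least 9.5-fold higher number from compound 1 to compound 2 (0.98 log units; beyond the scatter) and the step to compound 3 already given, and both start from compound 1, which carries a chlorophenyl group but no such carbonyl. Compound 4 has both features, so the value of compound 1 at 2090 nM is only a weak guide to it, and compound 3 at 18100 nM remains the better anchor. No step beyond the scatter is therefore expected, only an estimated 1.5-fold lower number from compound 3 to compound 4 (0.18 log units; within the scatter). Compound 4 is expected at 12000 nM, within an estimated range of 4000 nM to 20000 nM.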

Compound 4, half-maximal inhibitory concentration: 3180 nM
For compound 4 the middle estimate is 3.8-fold (0.58 log units) above the measured one; measured number outside the range, below it.
By their numbers in this assay, from the lowest: compounds 1 and 4 (each within the scatter of the next); then compound 3. At a limit, above all of these: compound 2.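

Compound 3 had left open whether the carbonyl itself went with the weaker number, and this result argues against that. With the carbonyl kept, 3-chlorophenyl in place of 2-methylphenyl gives a 5.7-fold lower number from compound 3 to compound 4 (0.76 log units; beyond the scatter), and (3-chlorophenyl)carbonyl in place of 2-chlorophenyl on an amine nitrogen gives only a 1.5-fold higher number from compound 1 to compound 4 (0.18 log units; within the scatter), so among these compounds a carbonyl at this position does not by itself separate a compound from compound 1. The remaining comparison reads as an at least 6.2-fold lower number from compound 2 to compound 4 (0.79 log units; beyond the scatter), and it is a floor set by a limit rather than a number: the limit of > 20000 nM in this assay, at which 1 of the 4 values shown sits.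

The step from compound 3 to compound 4 changes both the substituent and its place on the ring in one move, so the compounds shown do not tell which of the two matters. A (3-methylphenyl)carbonyl or (2-chlorophenyl)carbonyl group would separate them.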